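Sulfonamide Aryl Shrunk From Naphthyl to Methylphenyl

The source may hold more compounds than are shown below. What is called first, only, known or untested is meant among the compounds shown, and "the series" means these compounds.

The series shares one core and varies the group attached to the nitrogen on the cyclohexyl ring. Compound 1 `CCCN(CC[C@H]1CC[C@H](NC(=O)/C=C/c2ccccc2OC)CC1)[C@H]1CCc2nc(N)sc2C1` carries an amide; in an assay on brain for displacement of a labelled ligand from D(3) dopamine receptor (Rattus norvegicus) (a lower number here means a stronger inhibitor, a higher number a weaker inhibitor), compound 1 gives 8.1 nM. Compound 2 `CCCN(CC[C@H]1CC[C@H](NC(=O)c2cccc(-n3cncn3)c2)CC1)[C@H]1CCc2nc(N)sc2C1` keeps the amide with a different aryl, and compound 2 gives 3 nM; the change a 2.7-fold lower number from compound 1 to compound 2 (0.43 log units; beyond the scatter). Compound 3 `CCCN(CC[C@H]1CC[C@H](NS(=O)(=O)c2cccc3ccccc23)CC1)[C@H]1CCc2nc(N)sc2C1` carries a sulfonamide instead, and compound 3 gives 1.5 nM, the lowest of the three numbers, within the scatter of compound 2 and beyond it only against compound 1.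

Compound 4 `CCCN(CC[C@H]1CC[C@H](NS(=O)(=O)c2cccc(C)c2)CC1)[C@H]1CCc2nc(N)sc2C1` is the next step: 3-methylphenyl in place of naphthalen-1-yl on a sulfonyl sulfur. For the measured compounds named here, no measured step touches the group on the sulfonyl sulfur, so none bears directly on this change; the one measured step, between two amide aryl groups, was modest. Compound 4 is therefore expected to lose some of the inhibition of compound 3 as one aromatic ring is removed, and its step is estimated as a 2.7-fold higher number from compound 3 to compound 4 (0.43 log units; beyond the scatter). For compound 4 the expected value in this assay is 4 nM, with a range from 1.5 nM to 12 nM.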

Compound 4, inhibition constant: 0.89 nM
For compound 4 the middle estimate is 4.5-fold (0.65 log units) above the measured one, outside the stated range (below it).
By their numbers in this assay, from the lowest: compounds 4, 3 and 2 (each within the scatter of the next, the first and the last beyond it); then compound 1.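

On a sulfonyl sulfur, 3-methylphenyl in place of naphthalen-1-yl gives a 1.7-fold lower number from compound 3 to compound 4 (0.23 log units; within the scatter) in this assay, so the two compounds cannot be told apart in this assay, even though one of the two six-membered aromatic rings of carbon only leaves with naphthalen-1-yl. The earlier compounds shown here offered only a 2.7-fold lower number from compound 1 to compound 2 (0.43 log units; beyond the scatter), a change on a carbonyl carbon, and said nothing about the sulfonyl sulfur; this step shows that, in this pair, the second ring of naphthalen-1-yl can go without a change beyond the usual scatter. No measurement at hand accounts for this result.

With only these two sulfonamides, the compounds shown leave open what the methyl group on the ring contributes, and whether an unsubstituted phenyl, a 3-methoxyphenyl or an open propyl chain on the sulfonyl sulfur would stay in the same range. They also leave open how the sulfonamide compares with the amide when the aryl group is kept the same, since no pair shown differs in that one place alone.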